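A few compounds are considered here, and "the series" means these few. Any claim that something is new, unique, unknown or untested is made for them only; others in the source may bear on it.

Measured so far:
compound 1, `CCCNC(=O)[C@@H]1CN[C@H](C(=O)N2CCC[C@H]2C#N)C1`: 21%
compound 2, `C[C@@H]1N[C@H](C(=O)N2CCC[C@H]2C#N)C[C@@H]1C(=O)N1CCOCC1`: 85%

Both compounds were tested in an assay on the whole organism (plasma, strain Sprague-Dawley) for inhibition of Dipeptidyl peptidase 4 (Rattus norvegicus), with a stated time of 10 h, at a dose of 1 mg/kg by the oral route; on this read-out lower numbers stand for less inhibition and higher numbers for more inhibition at the one dose given (going by the name of the read-out). In this assay compound 1 gives 21%, the lowest of the two numbers shown, while compound 2 gives 85%, a number that lies beyond the scatter above it. Among the measured compounds shown here, compounds 1 and 2 differ in more than one place, so no single step can be read from this pair; their two values show only that one member of this pair reaches high inhibition while the other stays low.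

Compound 3, `N#C[C@@H]1CCCN1C(=O)[C@@H]1C[C@H](C(N)=O)CN1`, has not yet been measured. It is reached from compound 1 by one change: hydrogen in place of propyl on an amide-type nitrogen. The propylcarbamoyl group becomes a carbamoyl group, and the rest of the molecule stays the same.

For the measured compounds named here, no measured pair shows what this change does, so the expectation rests on the starting point of compound 1 at 21%. A change this small is expected to move the number only modestly, and the expected step is a number 9 percentage points higher from compound 1 to compound 3 (within the scatter), a slight rise that may stay within the scatter. Compound 3 is therefore expected to give about 30% in this assay, within a range from 10% to 55%.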

Compound 3, a percentage reported as inhibition, in the whole organism at one dose (the size of the read-out at that dose, not a potency): 20%
For compound 3 the middle estimate is 10 percentage points above the measured one; low and high end bracket the measured number.
By their numbers in this assay, from the lowest: compounds 3 and 1 (each within the scatter of the next); then compound 2.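

In this assay, taking the propyl group off the amide-type nitrogen and leaving hydrogen in its place gives a number 1 percentage points lower from compound 1 to compound 3 (within the scatter), so the two compounds cannot be told apart on this read-out. Among the compounds shown here, this is the first direct look at this position, and it shows that the propylcarbamoyl group and the plain carbamoyl group give numbers of the same size at this one oral dose and time, although the read-out is not a potency and a difference in potency could stay hidden. Nothing shown here explains this result.

From the compounds shown here alone, whether other groups on this nitrogen, such as a longer chain or a benzyl group, or a carboxylic acid in place of the carbamoyl group, would move the number beyond the scatter remains open. For the compounds shown here, compound 1 also differs in more than one place from compound 2, which gives 85% in this assay, so no step between them can be read, and what separates their numbers cannot be assigned to any single part of the structure.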